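Swapping Methylsulfanyl for Hydroxymethyl on a Shared Core

This account rests on a few compounds, and the source may have more. Where it says the series, first, only, none or still open, it means among the compounds named here.

Two compounds sharing one core differ only in the group on the aromatic ring. Compound 1 `O=C(CCCCCc1ccc(Cl)cc1)N1CCOC1=O` carries a chloro group, and in an assay on HEK293 cells for inhibition of N-acylethanolamine-hydrolyzing acid amidase (Rattus norvegicus), read by LC-MS, with a stated time of 30 min (on this read-out lower numbers stand for stronger inhibition and higher numbers for weaker inhibition), compound 1 gives 4600 nM. Compound 2 `CSc1ccc(CCCCCC(=O)N2CCOC2=O)cc1` carries a methylsulfanyl group in its place. In this assay compound 2 gives only a limit of the assay, > 20000 nM, so its true number is not known. The step of an at least 4.3-fold higher number from compound 1 to compound 2 (0.63 log units; beyond the scatter) is therefore known only as a bound, because compound 2 sits at the limit of > 20000 nM in this assay, at which 1 of the 2 values shown sits. Compound 2 thus stands at the weak end of what has been measured.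

Compound 3 `O=C(CCCCCc1ccc(CO)cc1)N1CCOC1=O` changes compound 2 in one place: hydroxymethyl in place of methylsulfanyl on an aromatic carbon. Among the compounds with values here, no measured step covers this exact exchange; the one step at hand, from chloro to methylsulfanyl, shows that a change at this position can move the number beyond the scatter. Starting from a limit, the step that the limit leaves unreadable from compound 2 to compound 3 is expected to be small or unresolved. Compound 3 is estimated at 25000 nM in this assay, with a range from 8000 nM to 80000 nM.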

Compound 3, half-maximal inhibitory concentration: 190 nM
Estimate against measurement, compound 3: 130-fold (2.12 log units) above, outside the stated range (below it).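

This position can do more than the earlier pair suggested: the first step seen there went toward weaker inhibition, whereas hydroxymethyl in place of chloro gives a 24-fold lower number from compound 1 to compound 3 (1.38 log units; beyond the scatter), making compound 3 the strongest inhibitor of the three in this assay. The size of a group, counted in heavy atoms, does not separate the next pair: methylsulfanyl and hydroxymethyl have the same count, and they differ in carrying sulfur or oxygen and in the hydrogen-bond donor that only hydroxymethyl has, yet the exchange gives an at least 100-fold lower number from compound 2 to compound 3 (2.02 log units; beyond the scatter). That large step is known only as a bound, with its true size possibly larger: the limit of > 20000 nM in this assay, at which 1 of the 3 values shown sits.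

The compounds shown cannot tell whether the gain depends on the hydrogen of the hydroxyl, and a methoxymethyl group, which keeps the oxygen without that hydrogen, would help to separate the two. They also leave open how far the effect extends along a longer chain such as hydroxyethyl, and how an amine or a carboxylic acid at this position would compare.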